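The source may report more compounds than this note shows. Statements on the series, on what has been measured and on what is new or still open speak of the compounds shown alone.

Working notes on the series.

Three compounds with a shared core have been run in a functional assay for inhibition, tested at 20 ug/mL (a higher number here means a stronger effect of the compound at the concentration tested, a lower number a weaker effect), so far, differing only in the aryl group carried on one aromatic carbon. Compound 1 `Cc1cc(O)c(C(C)C)cc1-c1cc(-c2ccco2)c(C#N)c(=O)[nH]1` gives 26% and compound 2 `COc1ccc(-c2cc(-c3cc(C(C)C)c(O)cc3C)[nH]c(=O)c2C#N)cc1OC` gives 25%. Compound 3 `Cc1cc(O)c(C(C)C)cc1-c1cc(-c2ccc(N(C)C)cc2)c(C#N)c(=O)[nH]1` returns the top number of the three at 30%, but neither gap to the others is beyond the scatter: a number 4 percentage points higher from compound 1 to compound 3 (within the scatter) and a number 5 percentage points higher from compound 2 to compound 3 (within the scatter). The third exchange, a number 1 percentage points lower from compound 1 to compound 2 (within the scatter), is equally flat.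

The next compound, compound 4 `COc1ccc(-c2cc(-c3cc(C(C)C)c(O)cc3C)[nH]c(=O)c2C#N)cc1`, differs from compound 3 as follows: methoxy in place of dimethylamino on an aromatic carbon. All three exchanges of the aryl group measured so far, each within the scatter, bear on this step, and compound 2, which already carries methoxy groups on the same ring, sits at the same level as the rest. No step beyond the scatter is therefore expected; the step of a number 3 percentage points lower from compound 3 to compound 4 (within the scatter) is estimated to stay inside it. Compound 4 is estimated to give 27%, with a range from 15% to 40%.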

Compound 4, a percentage reported as inhibition, at one concentration (the size of the read-out at that concentration, not a potency): 24%
Beside the measured number, compound 4's estimate is 3 percentage points above it, within the range that was stated.
By their numbers in this assay, from the lowest: compounds 4, 2, 1 and 3 (each within the scatter of the next).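

In this assay, methoxy in place of dimethylamino on the aromatic carbon para to a large group is a flat exchange (a number 6 percentage points lower from compound 3 to compound 4 (within the scatter)). Hydrogen in place of methoxy on the same ring is equally flat (a number 1 percentage points lower from compound 2 to compound 4 (within the scatter)), as is 4-methoxyphenyl in place of furan-2-yl (a number 2 percentage points lower from compound 1 to compound 4 (within the scatter)), so the simple 4-methoxyphenyl group adds a fourth aryl group at this position without any step beyond the scatter. No measurement is available that could account for this flat picture.

From the compounds shown here alone, it remains open whether a different kind of group at this position, such as a carboxylic acid or a longer alkyl chain in place of the aryl ring, would give a step beyond the scatter. All the numbers are read-outs at a single concentration, so any differences in potency among these compounds also remain open.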